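The source may report more compounds than this note shows. Statements on the series, on what has been measured and on what is new or still open speak of the compounds shown alone.

Compound 1 `CC(C)[C@@H](C(=O)N1CCC[C@H]1C(=O)N[C@@H](CCCNC(=N)N)C(=O)CF)N(C)C(=O)OCc1ccccc1`: > 20000 nM, a limit of the assay
Compound 2 `CC(C)[C@H](NC(=O)c1ccccc1)C(=O)N1CCC[C@H]1C(=O)N[C@@H](CCCNC(=N)N)C(=O)CF`: 660 nM
Compound 3 `CC(C)[C@H](NC(=O)c1ccc(Br)cc1)C(=O)N1CCC[C@H]1C(=O)N[C@@H](CCCNC(=N)N)C(=O)CF`: 130 nM

In a functional assay on OCI-Ly3 cells (Homo sapiens) for inhibition, read by CellTiter-Glo, with stated times of 48 h and 96 h (on this read-out higher numbers stand for weaker inhibition of growth and lower numbers for stronger inhibition of growth), compound 3 has the lowest number of the series, and compound 2 is its nearest neighbour. Compound 4 `CC(C)[C@H](NC(=O)c1ccc(Cl)cc1)C(=O)N1CCC[C@H]1C(=O)N[C@@H](CCCNC(=N)N)C(=O)CF` carries chloro in place of bromo on an aromatic carbon, para to a large group (chloro in place of bromo on an aromatic carbon). The most relevant measured change is at this same carbon: a 5.1-fold lower number from compound 2 to compound 3 (0.71 log units; beyond the scatter), a modest step beyond the scatter. The large steps of an at least 30-fold lower number from compound 1 to compound 2 (1.48 log units; beyond the scatter) and an at least 150-fold lower number from compound 1 to compound 3 (2.18 log units; beyond the scatter) involve a different group and bear little on this swap. Among the measured compounds shown here, no chloro and bromo pair has been measured, so only a small step is expected, well short of the change seen on adding bromo to compound 2, with a slight drift towards a higher number at most. The expected change is a 1.3-fold higher number from compound 3 to compound 4 (0.12 log units; within the scatter). Compound 4 is estimated at 170 nM, with a range of 70 nM to 420 nM.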

Compound 4, concentration for 50% growth inhibition: 1240 nM
Beside the measured number, compound 4's estimate is 7.3-fold (0.86 log units) below it, and the stated range ends below it.
By their numbers in this assay, from the lowest: compound 3; then compounds 2 and 4 (each within the scatter of the next). At a limit, above all of these: compound 1.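

In this assay the swap of bromo for chloro at this aromatic carbon gives a 9.5-fold higher number from compound 3 to compound 4 (0.98 log units; beyond the scatter) and shows that the two halogens are not interchangeable here. Against hydrogen, chloro gives a 1.9-fold higher number from compound 2 to compound 4 (0.27 log units; within the scatter) and so does not share the gain seen with bromo in compound 3. The step of an at least 16-fold lower number from compound 1 to compound 4 (1.20 log units; beyond the scatter) rests on a limit for compound 1: the limit of > 20000 nM in this assay, at which 1 of the 4 values shown sits.

Still open, on these data alone, is whether the gain is peculiar to bromo, or whether iodo, methyl or methoxy at this carbon would read like compound 3.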